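Biphenyl in place of tolyl: one step in a sulfonamide series

The source may hold more compounds than are shown below. What is called first, only, known or untested is meant among the compounds shown, and "the series" means these compounds.

Compound 1 `COc1ccc2c(c1)c(CC(=O)NS(=O)(=O)c1ccc(Cl)c([N+](=O)[O-])c1)c(C)n2-c1ccc(C)cc1` stands only at a limit in an assay on isolated protein for binding affinity to Apoptosis regulator Bcl-2 (Homo sapiens), read by fluorescence polarization, with stated times of 30 min and 20 min; a lower number here means a stronger inhibitor, a higher number a weaker inhibitor: there compound 1 gives > 10000 nM, which is a limit of the assay and not a number. Among the measured compounds shown here, compound 2 `COc1ccc(S(=O)(=O)NC(=O)Cc2c(C)n(-c3ccc(C)cc3)c3ccc(OC)cc23)cc1` is the only other compound with a value in this assay, and compound 2 gives > 10000 nM, again a limit and not a number. For the measured compounds named here, the one step joining these two, a step that the two limits leave unreadable from compound 1 to compound 2, therefore has no readable size; what the pair shows is the limit of > 10000 nM in this assay, at which 2 of the 2 values shown sit. Compound 3 `COc1ccc2c(c1)c(CC(=O)NS(=O)(=O)c1ccc(Cl)c([N+](=O)[O-])c1)c(C)n2-c1ccc(-c2ccccc2)cc1` is still unmeasured. It differs from compound 1 by phenyl in place of methyl on an aromatic carbon, the rest of compound 1 left unchanged. Going by the values given here, no measured step touches that place, so no direction can be read from the series. Compound 3 is expected to remain at the limit, because compound 1 gives > 10000 nM. The step that the limit leaves unreadable from compound 1 to compound 3 is estimated as nothing beyond the scatter. For compound 3 the estimate in this assay is 15000 nM, between 5000 nM and 50000 nM.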

Compound 3, inhibition constant: 720 nM
Compound 3: the middle estimate sits 21-fold (1.32 log units) above what was measured, and the stated range ends above it.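

In this assay there is an at least 13-fold lower number from compound 1 to compound 3 (1.14 log units; beyond the scatter), so the group on this aromatic carbon can move the series off its limit, and the size of the step is a bound and not an exact figure. The earlier pair could not show this: the step between compound 1 and compound 2 cannot be read, and it concerns the group on the sulfonyl sulfur, not this place. Compound 3, with 4-phenylphenyl in place of 4-methylphenyl, is the only compound shown that gives a number and not a limit: the limit of > 10000 nM in this assay, at which 2 of the 3 values shown sit.

Still open, as far as these compounds go, is whether an amine or a carboxylic acid on the entering phenyl, or a longer chain in its place, would keep a number in this assay. Also open, from the compounds shown here alone, is whether 4-phenylphenyl would do the same alongside 4-methoxyphenyl on the sulfonyl sulfur.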